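Swapping methoxy for trifluoromethyl on a cytotoxic amide

A few compounds are considered here, and "the series" means these few. Any claim that something is new, unique, unknown or untested is made for them only; others in the source may bear on it.

Of the compounds shown here, three built on one shared core have been measured in a functional assay on PC-3 cells (Homo sapiens) for cytotoxicity, read by MTT assay, with a stated time of 72 h; on this read-out lower numbers stand for stronger inhibition and higher numbers for weaker inhibition. Compound 1 `O=C(Nc1ccc(Oc2ccnc3[nH]ccc23)cc1)c1nccc(-c2cccc(Cl)c2)n1` gives 7800 nM. Compound 2 `COc1ccc(-c2cc(C(=O)Nc3ccc(Oc4ccnc5[nH]ccc45)cc3)ncn2)cc1` gives 9830 nM. Compound 3 `COc1ccc(-c2cc(C(=O)Nc3ccc(Oc4ccnc5[nH]ccc45)c(F)c3)ncn2)cc1` gives 2570 nM, the lowest of the three numbers; compound 1 sits nearest to it and compound 2 furthest. Among the measured compounds shown here, the only single-point step known here, a 3.8-fold lower number from compound 2 to compound 3 (0.58 log units; beyond the scatter), concerns a fluoro in place of hydrogen on an aromatic carbon, a change that compound 4 keeps.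

Compound 4 `O=C(Nc1ccc(Oc2ccnc3[nH]ccc23)c(F)c1)c1cc(-c2ccc(C(F)(F)F)cc2)ncn1` differs from compound 3 in one place: trifluoromethyl in place of methoxy on an aromatic carbon. For the measured compounds named here, no measured pair shows what this exchange does; the step from compound 2 to compound 3 touches a different part of the molecule, and compound 1 carries both a different pendant ring and a different arrangement of the central ring, so no clean comparison exists. Without such a precedent, the expected change in this assay is none beyond the scatter, so a 1.2-fold higher number from compound 3 to compound 4 (0.07 log units; within the scatter) is estimated to be small. Compound 4 is therefore expected to give about 3000 nM, within a range from 1000 nM to 9000 nM.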

Compound 4, half-maximal inhibitory concentration: 4120 nM
For compound 4 the middle estimate is 1.4-fold (0.14 log units) below the measured one; low and high end bracket the measured number.
By their numbers in this assay, from the lowest: compounds 3, 4, 1 and 2 (each within the scatter of the next, the first and the last beyond it).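

Among the compounds shown here, exchanging 4-methoxyphenyl for 4-(trifluoromethyl)phenyl gives a 1.6-fold higher number from compound 3 to compound 4 (0.20 log units; within the scatter) in this assay, the first reading of this change. In this one pair, then, the position para to a large group accepts either group without a difference that can be told from the usual scatter of the measurement, even though the two groups share only their carbon and differ in their other atoms. Nothing available here explains why the two compounds read alike.

On these data alone, whether a group of another kind at this position, such as an amine, a carboxylic acid or a longer chain, would shift the number remains open. Also open, as far as these compounds go, is whether the same exchange would read alike on compound 2, which has hydrogen in place of the fluoro.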